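Substituted benzamide amines on a sulfamate core

The compounds below may be only part of what the source reports. "The series", "measured", "known", "first", "only" and "open" are said of these compounds alone.

Measured so far in an assay on HEK293 cells for inhibition of Steryl-sulfatase (Homo sapiens), tested at 0.1 uM; a lower number here means a weaker effect, a higher number a stronger effect of the compound at the concentration tested:
compound 1 `CC(C)CCN(CCC(C)C)c1ccc(C(=O)N2CCc3ccc(OS(N)(=O)=O)cc3C2)cc1` gives 47%
compound 2 `CCN(Cc1ccccn1)c1ccc(C(=O)N2CCc3ccc(OS(N)(=O)=O)cc3C2)cc1` gives 42.5%
compound 3 `CCN(Cc1ccncc1)c1cccc(C(=O)N2CCc3ccc(OS(N)(=O)=O)cc3C2)c1` gives 33.3%

Compound 3 holds the lowest of the three numbers. Against compound 2 it lies within the scatter; against compound 1 the gap is beyond the scatter, so only that comparison marks compound 3 as weaker at this concentration.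

The next compound, compound 4 `CN(CCCN1CCCCC1)c1cccc(C(=O)N2CCc3ccc(OS(N)(=O)=O)cc3C2)c1`, differs from compound 3 in one place: methyl(3-(piperidin-1-yl)propyl)amino in place of ethyl((pyridin-4-yl)methyl)amino on an aromatic carbon.

Among the compounds with values here, only one measured step bears on this kind of change, the exchange of the amine substituent on the same aromatic carbon of the benzamide ring: a number 4.5 percentage points lower from compound 1 to compound 2 (within the scatter). That step was within the scatter, so a swap of the amino substituent has so far not shifted the read-out in this assay beyond the noise. Within the data shown here, no step from a pyridinylmethyl group to a piperidinylpropyl group has been measured, so the direction is open.

The step from compound 3 to compound 4 is therefore expected to be small, a number 2.7 percentage points higher from compound 3 to compound 4 (within the scatter), with no clear direction. Compound 4 is estimated at 36%, in the range 22% to 50%.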

Compound 4, a percentage reported as inhibition, at one concentration (the size of the read-out at that concentration, not a potency): 24.1%
Estimate against measurement, compound 4: 11.9 percentage points above; the measured number falls inside the stated range.
By their numbers in this assay, from the lowest: compounds 4, 3, 2 and 1 (each within the scatter of the next, the first and the last beyond it).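

In this assay, the exchange of ethyl((pyridin-4-yl)methyl)amino for methyl(3-(piperidin-1-yl)propyl)amino gives a number 9.2 percentage points lower from compound 3 to compound 4 (within the scatter), so the read-out does not separate these two groups on an aromatic carbon meta to a large group. This extends the earlier finding from a number 4.5 percentage points lower from compound 1 to compound 2 (within the scatter): here a six-membered non-aromatic ring with 1 hetero atom replaces the six-membered aromatic ring with 1 hetero atom, and the read-out still stays within the scatter. No measurement bears on what lies behind this step.

On these data alone, whether a morpholine ring or a carboxylic acid at the end of the propyl chain would move the read-out beyond the scatter remains open. With a single tested concentration, the potency of these compounds also remains open.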